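Methyl to trifluoromethyl on two related amide cores

The compounds below may be only part of what the source reports. "The series", "measured", "known", "first", "only" and "open" are said of these compounds alone.

Three compounds are measured in a functional assay on MCF7 cells (Homo sapiens) for cytotoxicity, read by MTT assay, with a stated time of 72 h; on this read-out lower numbers stand for stronger inhibition and higher numbers for weaker inhibition. Compound 1 `Cc1c(C(=O)Nc2ccc(Oc3ccnc4[nH]ccc34)c(F)c2)nnn1-c1ccc(F)c(F)c1` gives 820 nM, compound 3 `O=C(Nc1ccc(Oc2ccnc3[nH]ccc23)c(F)c1)c1nnn(-c2ccc(F)c(F)c2)c1C(F)(F)F` gives 590 nM, and compound 2 `Cc1c(C(=O)Nc2ccc(Oc3ccnc4[nH]ccc34)cc2)nnn1-c1ccccc1F` gives 280 nM, the lowest number of the three. The step of a 1.4-fold lower number from compound 1 to compound 3 (0.14 log units; within the scatter) rests on (trifluoromethyl in place of methyl on an aromatic carbon). The difference between the cores of compound 1 and compound 2 is not broken down here. Compound 4 `O=C(Nc1ccc(Oc2ccnc3[nH]ccc23)cc1)c1nnn(-c2ccccc2F)c1C(F)(F)F` is not yet measured; it carries the same kind of change, (trifluoromethyl in place of methyl on an aromatic carbon), the place differing in that the ring atom bears a 2-fluorophenyl group rather than a 3,4-difluorophenyl group. In this assay the expected step is a 1.3-fold lower number from compound 2 to compound 4 (0.10 log units; within the scatter), because the same kind of change gave a 1.4-fold lower number from compound 1 to compound 3 (0.14 log units; within the scatter). Compound 4 is estimated at 220 nM, with an expected range from 110 nM to 450 nM.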

Compound 4, half-maximal inhibitory concentration: 290 nM
Compound 4: the middle estimate sits 1.3-fold (0.12 log units) below what was measured; measured number inside the range.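

In this assay the step of a 1.0-fold higher number from compound 2 to compound 4 (0.02 log units; within the scatter) shows trifluoromethyl in place of methyl leaving the number within the scatter on this core as well. Set beside the earlier step, the two cores do not differ beyond the scatter: the same change on two cores in this assay, a 1.4-fold lower number (0.14 log units; within the scatter) from compound 1 to compound 3 and a 1.0-fold higher number (0.02 log units; within the scatter) from compound 2 to compound 4, 1.4-fold (0.16 log units) apart, within the scatter of two such steps. For the compounds shown here, this supports carrying the change between these two cores in this read-out, but with only two pairs it shows no gain from trifluoromethyl and says nothing about other cores.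

The compounds shown carry only methyl or trifluoromethyl on this aromatic carbon. Going by these compounds, whether a nitrile, an amine or a longer chain at that place would shift the number remains open.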